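The source may report more compounds than this note shows. Statements on the series, on what has been measured and on what is new or still open speak of the compounds shown alone.

Measured in a functional assay with Homo sapiens as the target; on this read-out lower numbers stand for stronger inhibition and higher numbers for weaker inhibition

- compound 1 `CC(C)[C@H](NC(=O)COc1cccc2ccccc12)C(=O)N[C@@H](CC(=O)O)C(=O)COc1ccccc1C(F)(F)F` gives 17300 nM
- compound 2 `CC(C)[C@H](NC(=O)COc1cccc2ccccc12)C(=O)N[C@@H](CC(=O)O)C(=O)COc1ccc(C(F)(F)F)cc1` gives 12300 nM
- compound 3 `CC(C)[C@H](NC(=O)COc1cccc2ccccc12)C(=O)N[C@@H](CC(=O)O)C(=O)COc1ccccc1F` gives 15700 nM

Compound 3 stands level with the other two, since its number lies within the scatter of both. Compound 4 `CC(C)[C@H](NC(=O)COc1cccc2ccccc12)C(=O)N[C@@H](CC(=O)O)C(=O)COc1ccc(F)cc1F` keeps the shared core and differs from compound 3 in one place: fluoro in place of hydrogen on an aromatic carbon. This is fluoro in place of hydrogen on an aromatic carbon, para to a large group and meta to a fluoro group, so 2-fluorophenyl becomes 2,4-difluorophenyl.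

For the measured compounds named here, three measured steps bear on this change. Exchanging 2-(trifluoromethyl)phenyl for 4-(trifluoromethyl)phenyl gave a 1.4-fold lower number from compound 1 to compound 2 (0.15 log units; within the scatter). Fluoro in place of trifluoromethyl gave a 1.1-fold lower number from compound 1 to compound 3 (0.04 log units; within the scatter). 2-Fluorophenyl in place of 4-(trifluoromethyl)phenyl gave a 1.3-fold higher number from compound 2 to compound 3 (0.11 log units; within the scatter). All three lie within the scatter. None of them adds a group to the ring of compound 3, so this exact change has not been tested. Still, no change to this ring so far has moved the number beyond the scatter, and none is expected here in this assay. The expected step is a 1.1-fold lower number from compound 3 to compound 4 (0.05 log units; within the scatter), which would be too small to read as a real difference. For compound 4 the estimated value is 14000 nM, with an expected range from 7500 nM to 26000 nM.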

Compound 4, half-maximal inhibitory concentration: 17600 nM
Estimate against measurement, compound 4: 1.3-fold (0.10 log units) below, and the stated range covers the measured number.
By their numbers in this assay, from the lowest: compounds 2, 3, 1 and 4 (each within the scatter of the next).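

In this assay, for the compounds shown here, the earlier compounds only exchanged one ring substituent for another, whereas compound 4 adds a second fluoro to a ring that already carries one, para to a large group and meta to the first fluoro, giving a 1.1-fold higher number from compound 3 to compound 4 (0.05 log units; within the scatter). The 2,4-difluorophenyl ring also stands level with both trifluoromethyl-bearing rings, at a 1.4-fold higher number from compound 2 to compound 4 (0.16 log units; within the scatter) and a 1.0-fold higher number from compound 1 to compound 4 (0.01 log units; within the scatter), so in this small set, neither the added fluoro nor the exchange of these groups can be told apart from the scatter of repeated measurements. Nothing available here explains why this ring position gives such a flat picture.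

As far as these compounds go, all four rings carry only fluoro or trifluoromethyl, so it remains open whether a plain phenyl or a ring bearing an amine, a hydroxyl or a carboxylic acid would move the number beyond the scatter in this assay. All four compounds also share the same core, which leaves open how much a change elsewhere in the molecule, such as a longer chain in place of the isopropyl-bearing part, would matter.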